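Swapping the Benzyl Aryl Group for a Naphthalene

This account rests on a few compounds, and the source may have more. Where it says the series, first, only, none or still open, it means among the compounds named here.

Compound 1 `O=S(=O)(NCCCNCc1ccccc1Cl)c1cc(C(F)(F)F)cc(C(F)(F)F)c1` gives 13000 nM in a functional assay on ASPC1 cells (Homo sapiens) for inhibition, read by MTT assay, with a stated time of 72 h; on this read-out higher numbers stand for weaker inhibition of growth and lower numbers for stronger inhibition of growth.
Compound 2 `O=S(=O)(NCCCNCc1ccc(Cl)c(Cl)c1)c1cc(C(F)(F)F)cc(C(F)(F)F)c1` gives 2800 nM in this assay.
Compound 3 `O=S(=O)(NCCCNCc1ccc(C(F)(F)F)cc1)c1cc(C(F)(F)F)cc(C(F)(F)F)c1` gives 2000 nM in this assay.

All three share one core and differ only in the aryl group on a saturated chain carbon bound to an amine nitrogen. Compound 3 has the lowest of the three numbers, but compound 2 sits within the scatter of it, so the two cannot be ranked against each other. Compound 4 `O=S(=O)(NCCCNCc1cccc2ccccc12)c1cc(C(F)(F)F)cc(C(F)(F)F)c1` carries the change (naphthalen-1-yl in place of 4-(trifluoromethyl)phenyl on a saturated chain carbon bound to an amine nitrogen). Among the compounds with values here, three measured steps bear on changes at this place: a 4.6-fold lower number from compound 1 to compound 2 (0.67 log units; beyond the scatter), a 6.5-fold lower number from compound 1 to compound 3 (0.81 log units; beyond the scatter) and a 1.4-fold lower number from compound 2 to compound 3 (0.15 log units; within the scatter). Two of these were modest and one lay within the scatter, and none of them involves naphthalen-1-yl, so a change at this place has so far moved the number by a modest amount or not at all. The expected step is a 1.3-fold higher number from compound 3 to compound 4 (0.10 log units; within the scatter), that is, no change beyond the scatter. Compound 4 is estimated at 2500 nM, with a range from 800 nM to 8000 nM.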

Compound 4, concentration for 50% growth inhibition: 21000 nM
Estimate against measurement, compound 4: 8.4-fold (0.92 log units) below, and the stated range ends below it.
By their numbers in this assay, from the lowest: compounds 3 and 2 (each within the scatter of the next); then compounds 1 and 4 (each within the scatter of the next).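

Naphthalen-1-yl in place of 4-(trifluoromethyl)phenyl gives an 11-fold higher number from compound 3 to compound 4 (1.02 log units; beyond the scatter) in this assay, a large step where earlier changes at this place were modest or within the scatter, even though the two groups have the same number of heavy atoms; in place of 3,4-dichlorophenyl it gives a 7.5-fold higher number from compound 2 to compound 4 (0.88 log units; beyond the scatter). Against 2-chlorophenyl it gives a 1.6-fold higher number from compound 1 to compound 4 (0.21 log units; within the scatter), so compound 1 and compound 4 cannot be ranked against each other, and both stand apart from compound 2 and compound 3 with higher numbers. Nothing measured here accounts for this loss of growth inhibition.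

The compounds shown leave open whether naphthalen-2-yl would behave like naphthalen-1-yl. From the compounds shown here alone, all four also keep the same propyl chain, so whether a longer chain would change the size of these steps remains unknown.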